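The source may hold more compounds than are shown below. What is called first, only, known or untested is meant among the compounds shown, and "the series" means these compounds.

Compound 1 `COc1cc(C(=O)N2CCC(O)C(C)C2)cc2nc(NCc3cc(Cl)ccn3)oc12` and compound 3 `COc1cc(C(=O)N2CC(C)OCC2CCO)cc2nc(NCc3cc(Cl)ccn3)oc12` are built on one shared core, while compound 2 `COc1cc(C(=O)N2CCC(O)C(C)C2)cn2nc(NCc3cccc(Cl)c3)nc12` rests on another; the difference between the two cores is not broken down here. In an ADME assay on cells (Hepatocyte, Rattus norvegicus, strain Wistar) for pharmacokinetics, read by LC-MS, with a stated time of 90 min, tested at 1 uM (on this read-out higher numbers stand for fast clearance and lower numbers for slow clearance), compound 1 gives 14.3 mL/min/kg, compound 3 gives 20 mL/min/kg, and compound 2 gives 35 mL/min/kg. The change that turns compound 1 into compound 3 is 5-(2-hydroxyethyl)-2-methylmorpholin-4-yl in place of 4-hydroxy-3-methylpiperidin-1-yl on a carbonyl carbon, and it made a step of a 1.4-fold higher number from compound 1 to compound 3 (0.15 log units; within the scatter). Compound 4 `COc1cc(C(=O)N2CC(C)OCC2CCO)cn2nc(NCc3cccc(Cl)c3)nc12` has not yet been measured in this assay. It carries the same change on the core of compound 2: 5-(2-hydroxyethyl)-2-methylmorpholin-4-yl in place of 4-hydroxy-3-methylpiperidin-1-yl on a carbonyl carbon. This change occurs only twice among these compounds, and only one of those two pairs is measured, so the expectation for compound 4 rests on a single step. Because the step of a 1.4-fold higher number from compound 1 to compound 3 (0.15 log units; within the scatter) lay within the scatter, compound 4 is expected to move by about the same amount, an estimated step of a 1.3-fold higher number from compound 2 to compound 4 (0.11 log units; within the scatter). The estimate for compound 4 is 45 mL/min/kg, with an expected range from 22 mL/min/kg to 90 mL/min/kg.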

Compound 4, clearance: 31.7 mL/min/kg
For compound 4 the middle estimate is 1.4-fold (0.15 log units) above the measured one, within the range that was stated.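

In this assay the same swap on the core of compound 2, 5-(2-hydroxyethyl)-2-methylmorpholin-4-yl in place of 4-hydroxy-3-methylpiperidin-1-yl on a carbonyl carbon, gives a step within the scatter (a 1.1-fold lower number from compound 2 to compound 4 (0.04 log units; within the scatter)). Set beside the earlier pair, the change reads alike on both cores: the same change on two cores in this assay, a 1.4-fold higher number (0.15 log units; within the scatter) from compound 1 to compound 3 and a 1.1-fold lower number (0.04 log units; within the scatter) from compound 2 to compound 4, 1.5-fold (0.19 log units) apart, within the scatter of two such steps. This shows that, on these two cores, the change carried over without a step beyond the scatter, but two pairs cannot show that it would do so on a further core, and they do not separate what the ring oxygen, the methyl and the 2-hydroxyethyl chain each contribute.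

The compounds shown leave open whether a plain morpholin-4-yl group, or a ring carrying an amine or a carboxylic acid in place of the hydroxyl, would give a step beyond the scatter on either core. Compound 1 and compound 2 also differ in more than one place, so the gap between them cannot be assigned to the core alone.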